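Stripping the hydroxypyrrolidine from compound 2

This account rests on a few compounds, and the source may have more. Where it says the series, first, only, none or still open, it means among the compounds named here.

Of the compounds shown here, two have been measured in an assay on isolated protein for inhibition of protein kinase C zeta type (Homo sapiens), read by mobility shift assay, tested at 30 uM; a lower number here means less inhibition, a higher number more inhibition at the concentration tested (going by the name of the read-out). Compound 1 `Cn1nc(N)c2c(=O)[nH]c(-c3ccccc3)cc21` gives 6% in this assay. Compound 2 `Cc1cc2c(c(N)nn2C)c(N2CC[C@H](O)C2)n1` gives 19% in this assay, which makes compound 2 the higher of the two numbers, and the gap between compound 2 and compound 1 is beyond the usual scatter of such measurements. Both values are small, so neither compound inhibits the enzyme strongly at the concentration tested.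

Compound 3 `Cc1cc2c(cn1)c(N)nn2C` has not yet been measured in this assay. It differs from compound 2 in one place: hydrogen in place of 3-hydroxypyrrolidin-1-yl on an aromatic carbon. The 3-hydroxypyrrolidin-1-yl group with its one hydrogen-bond donor and two hydrogen-bond acceptors is removed and nothing but a hydrogen atom takes its place.

Going by the values given here, no measured pair of compounds here follows a single change, so there is no directly comparable step to lean on. Since compound 2 already sits low, the room for a further fall is limited, and the step of a number 9 percentage points lower from compound 2 to compound 3 (within the scatter) is expected to be a modest drop, most likely within the scatter. Compound 3 is therefore expected to give about 10% in this assay, with a plausible range from 0% to 22%.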

Compound 3, a percentage reported as inhibition, at one concentration (the size of the read-out at that concentration, not a potency): -59%
Compound 3: middle estimate off by 69 percentage points, on the high side; the whole stated range lies above it.
By their numbers in this assay, from the lowest: compound 3; then compound 1; then compound 2.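

In this assay, putting hydrogen in place of 3-hydroxypyrrolidin-1-yl on the aromatic carbon next to the ring nitrogen leads to a number 78 percentage points lower from compound 2 to compound 3 (beyond the scatter). Going by these compounds alone, this is the first change in the set that can be read on its own, and it shows that this position is not a neutral spot: what sits there has a large bearing on the read-out, even though compound 2 itself inhibits only weakly. Compound 3 reads -59%, and a reading below zero gives no sign of inhibition at the concentration tested, so the small inhibition seen with compound 2 does not remain once the group is gone.

Nothing available accounts for the size of this drop, so it stands as an observation without an explanation. Still open, from the compounds shown here alone, is whether the hydroxyl group or the five-membered ring carries the effect, which a plain pyrrolidine could separate, and whether a simple amine such as dimethylamino, or a morpholine, on the same aromatic carbon would keep, lose or raise the inhibition.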